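Cytotoxicity Limits and a tert-Butyl Change on Compound 1

The source may report more compounds than this note shows. Statements on the series, on what has been measured and on what is new or still open speak of the compounds shown alone.

Compound 1 `CN(C)c1cc2[nH]c(C3CCCCC3)nc2cc1NC(=O)c1ccccc1` gives > 100 ug/mL in an ADME assay on Vero cells (Chlorocebus sabaeus) for cytotoxicity, read by resazurin assay, with a stated time of 3 days (on this read-out lower numbers stand for stronger inhibition and higher numbers for weaker inhibition), a limit of the assay.
Compound 2 `COCCOC(=O)Nc1cc2nc(C3CCCCC3)[nH]c2cc1N1CCCC1` gives > 100 ug/mL, again a limit.
Compound 3 `CCCCOC(=O)Nc1cc2nc(C3CCCCC3)[nH]c2cc1N(C)CCN(C)C` gives > 100 ug/mL, also a limit.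

In this assay compound 1 therefore stands only at a limit, not at a number. The same holds for compound 2 and compound 3, so that all three values rest at the limit of > 100 ug/mL in this assay, at which 3 of the 3 values shown sit. Compound 4 `CN(C)c1cc2[nH]c(C3CCCCC3)nc2cc1NC(=O)c1ccc(C(C)(C)C)cc1` differs from compound 1 by tert-butyl in place of hydrogen on an aromatic carbon. No step between measured compounds is available, so the size of this change cannot be read from the data; with every shown value resting at the limit, no step beyond the scatter is expected in either direction. Compound 4 is expected to give 100 ug/mL, between 40 ug/mL and 200 ug/mL, a step of a number no higher from compound 1 to compound 4 (the limit leaves the size open) expected to be none beyond the scatter.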

Compound 4, half-maximal inhibitory concentration: > 100 ug/mL
Compound 4: a limit, no number; the forecaster's own chance of this, stated with the estimate: 70%; the middle value lies on the limit itself.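

No step from compound 1 to compound 4 can be read in this assay, for the two compounds rest at the same limit: the limit of > 100 ug/mL in this assay, at which 4 of the 4 values shown sit.

The compounds shown leave open what number any of the four would give in this assay.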